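The compounds below may be only part of what the source reports. "The series", "measured", "known", "first", "only" and "open" are said of these compounds alone.

Of the compounds shown here, three sharing one core have been tested in a functional assay on MKN-45 cells (Homo sapiens) for cytotoxicity, read by MTT assay, with a stated time of 48 h; on this read-out lower numbers stand for stronger inhibition and higher numbers for weaker inhibition. Compound 1 `Cc1ccc(C(=O)CSc2nnc(C)n2N2C(=O)c3ccccc3C2=O)cc1` gives > 200000 nM, which is a limit of the assay rather than a number. Compound 2 `C=CCSc1nnc(CCC)n1N1C(=O)c2ccccc2C1=O` gives > 200000 nM, again only a limit. Compound 3 `C#CCSc1nnc(-c2cc(OC)c(OC)c(OC)c2)n1N1C(=O)c2ccccc2C1=O` gives > 200000 nM, a limit as well. Compound 3 therefore stands together with the other two at the limit of > 200000 nM in this assay, at which 3 of the 3 values shown sit, and none of the three can be set above or below another on these numbers.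

Compound 4 `COc1cc(-c2nnc(SCC(=O)c3ccc(F)c(F)c3)n2N2C(=O)c3ccccc3C2=O)cc(OC)c1OC` has not been measured. It differs from compound 3 in a single place: (3,4-difluorophenyl)carbonyl in place of ethynyl on a saturated chain carbon bound to a sulfur. Compound 1, which likewise carries a carbonyl-bearing group on a saturated chain carbon bound to a sulfur, gives > 200000 nM, a limit only. On that basis no step beyond the scatter is expected in either direction; the expected step is a number no higher from compound 3 to compound 4 (the limit leaves the size open). Compound 4 is expected to give 200000 nM in this assay, within 60000 nM to 600000 nM, most likely reported again as a limit only.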

Compound 4, half-maximal inhibitory concentration: > 200000 nM
Compound 4: only a limit was reported (the forecaster's own chance of this, stated with the estimate: 75%); the middle value lies on the limit itself.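

Compound 4 gives > 200000 nM, which is a limit and not a number. Compound 3 also has only a limit, so no step can be read from compound 3 to compound 4. The compounds shown leave open whether any group on the shared core can bring a readable number, as all values stand together: the limit of > 200000 nM in this assay, at which 4 of the 4 values shown sit.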